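A few compounds are considered here, and "the series" means these few. Any claim that something is new, unique, unknown or untested is made for them only; others in the source may bear on it.

Compound 2 `CC1=CC[C@H](C(C)(C)NC(=S)N/N=C/c2ccc(F)cc2)CC1` carries a 4-fluorophenyl group on the carbon with a double bond to nitrogen. In a functional assay on OVCAR-3 cells (Homo sapiens) for inhibition, read by sulforhodamine B assay, with a stated time of 48 h (a higher number here means a weaker inhibitor of growth, a lower number a stronger inhibitor of growth), compound 2 reaches only the limit of the test, > 100000 nM. Compound 1 `CC1=CC[C@H](C(C)(C)NC(=S)N/N=C/c2ccc(N(C)C)cc2)CC1` also sits at a limit in this assay, > 100000 nM. Compound 3 `CC1=CC[C@H](C(C)(C)NC(=S)N/N=C/c2ccccc2[N+](=O)[O-])CC1` gives a number in this assay, 8500 nM. The step that the two limits leave unreadable from compound 1 to compound 2 cannot be sized because both of its ends sit at the limit of > 100000 nM in this assay, at which 2 of the 3 values shown sit. Compound 4 `CC1=CC[C@H](C(C)(C)NC(=S)N/N=C/c2cccs2)CC1` differs from compound 2 by thiophen-2-yl in place of 4-fluorophenyl on a carbon with a double bond to nitrogen. No measured step covers this change, and the single step that is shown is unreadable, so the direction of the change is uncertain. The step of a number no higher from compound 2 to compound 4 (the limit leaves the size open) is estimated to be small at best. Compound 4 is therefore expected to give 100000 nM, within 20000 nM to 300000 nM, with a fair chance of again reaching only a limit.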

Compound 4, concentration for 50% growth inhibition: 13100 nM
For compound 4 the middle estimate is 7.6-fold (0.88 log units) above the measured one; measured number below the stated range.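

Replacing 4-fluorophenyl with thiophen-2-yl gives an at least 7.6-fold lower number from compound 2 to compound 4 (0.88 log units; beyond the scatter) in this assay, the only readable step shown at this carbon with a double bond to nitrogen. The group here can therefore bring a compound from the limit of the test to a measurable number, and a five-membered aromatic ring holding sulfur is enough to do so. The full size of the step stays open because one end is a limit: the limit of > 100000 nM in this assay, at which 2 of the 4 values shown sit.

As far as these compounds go, whether the sulfur atom or the smaller ring matters remains open. Furan-2-yl, which has oxygen in place of sulfur, or unsubstituted phenyl would help separate the two.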